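From phenyl to 3-fluorophenyl in compound 3

The compounds below may be only part of what the source reports. "The series", "measured", "known", "first", "only" and "open" are said of these compounds alone.

compound 1 `N#Cc1ccccc1Oc1ccc([C@H]2CC[C@@H](C(N)=O)N2)cc1` gives 1.8 mL.min-1.g-1
compound 2 `NC(=O)[C@@H]1CC[C@H](c2ccc(OCc3ccccc3)cc2)N1` gives 0.5 mL.min-1.g-1
compound 3 `NC(=O)[C@@H]1CC[C@H](c2ccc(Oc3ccccc3)cc2)N1` gives 1.9 mL.min-1.g-1

In an ADME assay on microsomes from liver (Rattus norvegicus) for metabolic stability (on this read-out higher numbers stand for fast clearance and lower numbers for slow clearance), compound 3 gives 1.9 mL.min-1.g-1 and cannot be told apart from compound 1 on these numbers. Placing phenyl where benzyl stood on the oxygen produced a modest step, a 3.8-fold higher number from compound 2 to compound 3 (0.58 log units; beyond the scatter), so compound 2 sits clearly apart from the other two.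

The next compound is compound 4 `NC(=O)[C@@H]1CC[C@H](c2ccc(Oc3cccc(F)c3)cc2)N1`, and the change leading to it is small: fluoro in place of hydrogen on an aromatic carbon. In words, this is fluoro in place of hydrogen on an aromatic carbon, meta to a large group.

Going by the values given here, no measured compound carries fluoro, so no step speaks to this change directly. The closest guide is hydrogen in place of cyano on an aromatic carbon, which gave a 1.1-fold higher number from compound 1 to compound 3 (0.02 log units; within the scatter) and so moved the number by no more than the scatter. The step from benzyl to phenyl is a different kind of change and carries less weight here.

On that basis, no shift beyond the scatter is expected in this assay. The expected step is a 1.1-fold higher number from compound 3 to compound 4 (0.02 log units; within the scatter) and could go either way. Compound 4 is estimated at 2 mL.min-1.g-1, with an expected range from 1.1 mL.min-1.g-1 to 3.5 mL.min-1.g-1 as its bounds.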

Compound 4, intrinsic clearance in microsomes: 2 mL.min-1.g-1
Beside the measured number, compound 4's estimate shows no gap at the digits printed, within the range that was stated.
By their numbers in this assay, from the lowest: compound 2; then compounds 1, 3 and 4 (each within the scatter of the next).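

In this assay, going by these compounds alone, fluoro in place of hydrogen on an aromatic carbon, meta to a large group, gives a 1.1-fold higher number from compound 3 to compound 4 (0.02 log units; within the scatter), so this is the first direct reading of a fluoro group at this place, and on these numbers compound 3 and compound 4 cannot be told apart. The larger difference in this set still lies in the link to the outer ring: 3-fluorophenyl in place of benzyl on the oxygen gives a 4.0-fold higher number from compound 2 to compound 4 (0.60 log units; beyond the scatter), which leaves compound 2 clearly apart from compound 4, just as it stands apart from compound 3. No measurement shown here explains why the fluoro step is so small or why the benzyl compound stands apart.

Going by these compounds, a single fluorine is only one small substituent at one place, so it remains open whether a larger or differently built group there, such as trifluoromethyl, methoxy or an amine, would also stay within the scatter. On these data alone, it is also open whether a 3-fluorobenzyl group on the oxygen, or a longer chain in that link, would give a number closer to that of compound 2 or of compound 4.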